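The compounds below may be only part of what the source reports. "The series", "measured", "known", "first", "only" and "open" are said of these compounds alone.

Measured in a functional assay on NCI-H727 cells (Homo sapiens) for antiproliferative activity, with a stated time of 48 h; on this read-out lower numbers stand for stronger inhibition and higher numbers for weaker inhibition:
Compound 1 `CC(=O)c1ccc(-c2ccc(N3CCCC3)nn2)cc1`: > 25000 nM (a limit of the assay)
Compound 2 `CCN(CC)c1ccc(-c2ccc(C(C)=O)cc2)nn1`: 25000 nM

Among the measured compounds shown here, compound 2 holds the only actual number so far, at the weak end of the values shown. Compound 3 `CCN(CC)c1ccc(-c2ccc(C(=O)O)cc2)nn1` carries hydroxy in place of methyl on a carbonyl carbon, which reads as acetyl to carboxy. For the measured compounds named here, the one measured step, a number no higher from compound 1 to compound 2 (the limit leaves the size open), lies at a different place, and its size cannot be read because of the limit of > 25000 nM in this assay, at which 1 of the 2 values shown sits. Going by the values given here, no measured step therefore bears on this change, and in this assay the expected no change at the digits printed from compound 2 to compound 3 (within the scatter) is none beyond the scatter. For compound 3 the estimate is 25000 nM, with an expected range of 10000 nM to 50000 nM.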

Compound 3, half-maximal inhibitory concentration: > 25000 nM
Compound 3: only a limit was reported; the forecaster's own chance of this, stated with the estimate: 50%; the middle value sits exactly at the limit.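

In this assay compound 3 gives > 25000 nM, which is a limit of the assay. Acetyl to carboxy thus gives a number no lower from compound 2 to compound 3 (the limit leaves the size open), and this is the first reading for a change at this carbonyl carbon. The sizes of this step and of the earlier step at the other place cannot be read: the limit of > 25000 nM in this assay, at which 2 of the 3 values shown sit.

Going by these compounds, whether a primary amide or a longer ketone chain at this carbonyl carbon would give a number clear of this limit stays open. On these data alone, how far compound 1 and compound 3 lie past the limit also stays open.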